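A few compounds are considered here, and "the series" means these few. Any claim that something is new, unique, unknown or untested is made for them only; others in the source may bear on it.

In an ADME assay on microsomes from liver (Mus musculus) for metabolic stability, read by mass spectrometry, using NADPH, tested at 1.5 uM (a lower number here means that the compound disappears faster, a higher number that the compound lasts longer), compound 2 `O=C(Nc1ccc2sc(-c3ccccc3)nc2c1)N1CCCCC1` gives 0.283 h, and compound 3 `O=C(Nc1ccc2oc(-c3ccccc3)nc2c1)c1ccccc1` gives the same number, 0.283 h. Compound 1 `O=C(Nc1ccc2sc(-c3cccc(F)c3)nc2c1)N1CCCCC1`, at 0.183 h, lies within the scatter of compound 2. All three numbers therefore sit close together, and none of these compounds can be said to last longer than the others.

The next compound to consider is compound 4 `O=C(Nc1ccc2sc(-c3ccccc3)nc2c1)c1ccccc1`. Reaching it from compound 2 involves (phenyl in place of piperidin-1-yl on a carbonyl carbon). In words, this is phenyl in place of piperidin-1-yl on a carbonyl carbon, which can also be read as (piperidin-1-yl)carbonyl to benzoyl.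

Going by the values given here, only one measured step is available, a 1.5-fold higher number from compound 1 to compound 2 (0.19 log units; within the scatter). It is a different change, hydrogen in place of fluoro on an aromatic carbon, so it says little directly about this exchange beyond showing a small movement. Among the compounds with values here, the closest guide is compound 3, which also carries benzoyl and gives 0.283 h, although no single-place step connects it to the other compounds. On this thin evidence, no shift beyond the scatter is expected, and the estimated step is a 1.0-fold lower number from compound 2 to compound 4 (0.00 log units; within the scatter). For compound 4, the estimated half-life is 0.28 h, with an expected range from 0.14 h to 0.55 h.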

Compound 4, half-life: 0.833 h
Compound 4: the middle estimate sits 3.0-fold (0.47 log units) below what was measured; measured number above the stated range.
By their numbers in this assay, from the lowest: compounds 1, 2 and 3 (each within the scatter of the next); then compound 4.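

In this assay, going by these compounds alone, the group on the carbonyl carbon is the first place in this set where a change in one place moves the half-life beyond the scatter: the step is a 2.9-fold higher number from compound 2 to compound 4 (0.47 log units; beyond the scatter), which is modest in size. The two groups have the same number of heavy atoms and neither has hydrogen-bond donors or acceptors, so those counts do not separate them; they differ in that piperidin-1-yl is a non-aromatic ring containing nitrogen, whereas phenyl is an aromatic ring of carbon only. Nothing available here explains why the number rises with this exchange.

One step cannot show which of those differences matters, and a cyclohexyl or a morpholin-4-yl group at this place would help to separate the roles of the ring nitrogen and the aromatic ring. Benzoyl alone does not fix the number either, since compound 3, which also carries it on a different core, gives 0.283 h, while compound 4 gives 0.833 h, so it remains open how far this exchange would carry over to other cores.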